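Swapping a Dimethylamino for a Glycolamide: Clearance Outlook

The compounds below may be only part of what the source reports. "The series", "measured", "known", "first", "only" and "open" are said of these compounds alone.

Compound 1 `Cc1cc(OCc2ccc(F)cc2F)c(Br)c(=O)n1Cc1ccc(CN(C)C)cc1` was tested in an in vivo ADME assay on the whole organism (strain Sprague-Dawley) for pharmacokinetics, with Rattus norvegicus as the target (on this read-out lower numbers stand for slow clearance and higher numbers for fast clearance), and gave 70 mL/min/kg, the higher of the two numbers recorded, since compound 2 `Cc1cnc(-n2c(C)cc(OCc3ccc(F)cc3F)c(Br)c2=O)cn1` gave 21.5 mL/min/kg in this assay, a gap beyond the usual scatter. Compound 3 `Cc1cc(OCc2ccc(F)cc2F)c(Br)c(=O)n1Cc1ccc(CNC(=O)CO)cc1` differs from compound 1 in one place: ((hydroxymethyl)carbonyl)amino in place of dimethylamino on a saturated chain carbon bound to an aromatic carbon. Compound 2 is built differently and offers no guide for this change, so any expectation rests on compound 1 alone. The step of a 1.8-fold lower number from compound 1 to compound 3 (0.24 log units; within the scatter) is expected to be a modest fall, of a size that may only just exceed the scatter. For compound 3 the estimate is 40 mL/min/kg, with a range from 15 mL/min/kg to 90 mL/min/kg.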

Compound 3, clearance: 26.2 mL/min/kg
Beside the measured number, compound 3's estimate is 1.5-fold (0.18 log units) above it; the measured number falls inside the stated range.
By their numbers in this assay, from the lowest: compounds 2 and 3 (each within the scatter of the next); then compound 1.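

In this assay, putting ((hydroxymethyl)carbonyl)amino in place of dimethylamino on a saturated chain carbon bound to an aromatic carbon gives a 2.7-fold lower number from compound 1 to compound 3 (0.43 log units; beyond the scatter), a modest step beyond the scatter. Within the data shown here, this is the first direct sign that clearance in the rat responds to the group at this place while the rest of the molecule stays the same. Nothing measured here explains the fall. Still open, as far as these compounds go, is whether a plain acetylamino group, without the hydroxyl, or a carboxylic acid at this place would shift clearance in the same direction.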